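The compounds below may be only part of what the source reports. "The series", "measured", "known", "first", "only" and "open" are said of these compounds alone.

In a physicochemical assay for lipophilicity, using the shake flask method, in phosphate buffer, measured as octanol-water partition, with a stated time of 24 h, at pH 7.4 (on this read-out lower numbers stand for lower lipophilicity and higher numbers for higher lipophilicity), compound 1 `O=S1(=O)CCc2c(C3CC3)nn(-c3ccccc3F)c2O1` gives 2.09, compound 2 `O=S1(=O)CC(c2ccc(F)cc2)c2c(C3CC3)nn(-c3ccccc3F)c2O1` gives 1.76 and compound 3 `COc1cccc(C2CS(=O)(=O)Oc3c2c(C2CC2)nn3-c2ccccc2F)c1` gives 2.01. Compound 3 therefore lies within the scatter of both other compounds. The measured steps are all small. Placing 4-fluorophenyl on the saturated ring carbon gave a number 0.33 log units lower from compound 1 to compound 2 (beyond the scatter), and placing 3-methoxyphenyl there gave a number 0.08 log units lower from compound 1 to compound 3 (within the scatter). Among the compounds with values here, exchanging the first group for the second gave a number 0.25 log units higher from compound 2 to compound 3 (within the scatter), the closest precedent for the next change.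

Compound 4 `Cc1cc(C2CS(=O)(=O)Oc3c2c(C2CC2)nn3-c2ccccc2F)ccc1Br` has 4-bromo-3-methylphenyl in place of 3-methoxyphenyl on a saturated ring carbon. Within the data shown here, no measured pair covers this exchange, so those steps suggest only that such swaps have stayed small here. The direction is a tentative expectation, and the range is kept wide. The expected change is a number 0.49 log units higher from compound 3 to compound 4 (beyond the scatter), a modest rise. For compound 4 the estimated value is 2.5, with an expected range of 2 to 3.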

Compound 4, partition coefficient: 2.72
Compound 4: the middle estimate sits 0.22 log units below what was measured; low and high end bracket the measured number.
By their numbers in this assay, from the lowest: compounds 2, 3 and 1 (each within the scatter of the next, the first and the last beyond it); then compound 4.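

On this saturated ring carbon, the two earlier phenyl groups left the number in this assay level with hydrogen or under it, whereas 4-bromo-3-methylphenyl in place of hydrogen gave a number 0.63 log units higher from compound 1 to compound 4 (beyond the scatter) and so showed that a group here can also carry the number upward. Exchanging one phenyl group for another is also not always a small step at this position: 4-bromo-3-methylphenyl gave a number 0.71 log units higher from compound 3 to compound 4 (beyond the scatter) in place of 3-methoxyphenyl and a number 0.96 log units higher from compound 2 to compound 4 (beyond the scatter) in place of 4-fluorophenyl. No supporting information is available to explain these rises.

The compounds shown leave open how much of the rise belongs to the bromine and how much to the methyl, which enter together. Also open, going by these compounds, is how an amine, a carboxylic acid or a longer chain on this carbon would read in this assay at this pH.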